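Nitro for Chloro on a Cinnamamide Sultam Series

This account rests on a few compounds, and the source may have more. Where it says the series, first, only, none or still open, it means among the compounds named here.

Of the compounds shown here, three sharing one core have been tested in a functional assay on HeLa cells (Homo sapiens) for inhibition, read by sulforhodamine B assay, with a stated time of 48 h; a lower number here means a stronger inhibitor of growth, a higher number a weaker inhibitor of growth. Compound 1 `COc1cc(/C=C/C(=O)N2CCC=CS2(=O)=O)cc(OC)c1OC` gives 14300 nM. Compound 3 `O=C(/C=C/c1c[nH]c2ccc(F)cc12)N1CCC=CS1(=O)=O` gives 18800 nM. Compound 2 `O=C(/C=C/c1ccc(Cl)cc1)N1CCC=CS1(=O)=O` gives 26400 nM, the highest of the three numbers, yet its gaps to compound 3 and to compound 1 both fall within the scatter of repeated measurements, so no real difference among the three can be claimed.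

The next compound, compound 4 `O=C(/C=C/c1ccc([N+](=O)[O-])cc1)N1CCC=CS1(=O)=O`, differs from compound 2 in one place: nitro in place of chloro on an aromatic carbon, para to a large group. Among the measured compounds shown here, no measured pair in this set shows what such a swap does to the read-out, so there is no step to lean on. Given that the three measured compounds sit together despite quite different aromatic parts, the expectation for compound 4 is a step of a 1.2-fold lower number from compound 2 to compound 4 (0.08 log units; within the scatter), not beyond the scatter in either direction. Compound 4 is therefore estimated at 22000 nM, with a plausible range from 9000 nM to 55000 nM.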

Compound 4, concentration for 50% growth inhibition: 24400 nM
The estimate for compound 4 lay 1.1-fold (0.04 log units) below the measured number, within the range that was stated.
By their numbers in this assay, from the lowest: compounds 1, 3, 4 and 2 (each within the scatter of the next).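

In this assay, among the compounds shown here, putting nitro in place of chloro on an aromatic carbon, para to a large group, gives a 1.1-fold lower number from compound 2 to compound 4 (0.03 log units; within the scatter) and so provides the first pair in this set that differs in one place. The entering group has three heavy atoms against one and two hydrogen-bond acceptors against none, yet this difference leaves no change in growth inhibition that can be told from the scatter. No measurement shown here offers an explanation for this flat step, so it stands as an observation only.

From the compounds shown here alone, one swap at one position is a narrow basis, and it remains open whether an amine or a carboxylic acid at this place would also leave the number unchanged. For the compounds shown here, it is also open whether the same swap would give so small a step on a different aromatic part, such as the one in compound 3.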